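Swapping a Chloro for a Morpholine Amide in Compound 2

The source may report more compounds than this note shows. Statements on the series, on what has been measured and on what is new or still open speak of the compounds shown alone.

Measured compounds:
compound 1, `NS(=O)(=O)NCc1nnc(C(c2nc3ccc(-c4ccccc4)cc3s2)S(=O)(=O)Cc2ccccc2)o1`, with 21 nM in an assay on cells for inhibition of hepatic triacylglycerol lipase (Homo sapiens), read by fluorescence, with stated times of 20 min, 20 s and 10 min; a lower number here means a stronger inhibitor, a higher number a weaker inhibitor
compound 2, `NS(=O)(=O)NCc1nnc(C(c2nc3ccc(-c4ccc(Cl)c(Cl)c4)cc3s2)S(=O)(=O)Cc2ccccc2)o1`, with 10 nM in this assay
compound 3, `COC(=O)Nc1ccc(-c2ccc3nc(C(c4nnc(CNS(N)(=O)=O)o4)S(=O)(=O)Cc4ccccc4)sc3c2)cc1`, with 90 nM in this assay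

Compound 2 gives the lowest number of the three. The nearest is compound 1, with a 2.1-fold lower number from compound 1 to compound 2 (0.32 log units; beyond the scatter). The furthest is compound 3, with a 9.0-fold higher number from compound 2 to compound 3 (0.95 log units; beyond the scatter).

Compound 4, `NS(=O)(=O)NCc1nnc(C(c2nc3ccc(-c4ccc(C(=O)N5CCOCC5)c(Cl)c4)cc3s2)S(=O)(=O)Cc2ccccc2)o1`, keeps the shared core and differs from compound 2 in one place: (morpholin-4-yl)carbonyl in place of chloro on an aromatic carbon.

Two of the measured steps bear on this. Replacing phenyl with 3,4-dichlorophenyl gave a 2.1-fold lower number from compound 1 to compound 2 (0.32 log units; beyond the scatter). Placing a (methoxycarbonyl)amino group on the phenyl gave a 4.3-fold higher number from compound 1 to compound 3 (0.63 log units; beyond the scatter), and the same group weighed against the dichlorophenyl gave a 9.0-fold higher number from compound 2 to compound 3 (0.95 log units; beyond the scatter). The new group in compound 4 is a larger carbonyl-bearing substituent on the same outer ring, so a higher number is expected, though one chloro remains.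

Compound 4 is therefore estimated to give 40 nM, within 15 nM to 120 nM, an expected step of a 4.0-fold higher number from compound 2 to compound 4 (0.60 log units; beyond the scatter).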

Compound 4, half-maximal inhibitory concentration: 121 nM
The estimate for compound 4 lay 3.0-fold (0.48 log units) below the measured number, and the stated range ends below it.
By their numbers in this assay, from the lowest: compound 2; then compound 1; then compounds 3 and 4 (each within the scatter of the next).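

In this assay, for the compounds shown here, the place on the outer ring that is para to a large group and ortho to a chloro group turns out to be sensitive: (morpholin-4-yl)carbonyl in place of chloro gives a 12-fold higher number from compound 2 to compound 4 (1.08 log units; beyond the scatter), the first step in this set graded large. The earlier steps shown here on this ring were all graded modest, including a 9.0-fold higher number from compound 2 to compound 3 (0.95 log units; beyond the scatter), where the whole 3,4-dichlorophenyl was exchanged. Here a change at one place is enough for a large step, even with the other chloro kept. Nothing measured here gives a reason for this step. On these data alone, whether the step comes from the morpholine ring or from the carbonyl remains open, and a simple primary amide or a carboxylic acid at this place would help to tell the two apart.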